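Working notes: from compound 2 to compound 3

A few compounds are considered here, and "the series" means these few. Any claim that something is new, unique, unknown or untested is made for them only; others in the source may bear on it.

Going by the values given here, compound 2 `CNC(=O)c1cc(Oc2ccc3nc(NC(=O)c4ccc(Cl)cc4Cl)sc3c2)ccn1` gives 81% in a functional assay on SK-BR-3 cells (Homo sapiens) for inhibition, read by MTT assay, with a stated time of 2 days, tested at 100 uM (on this read-out lower numbers stand for less inhibition of growth and higher numbers for more inhibition of growth at the one concentration tested), the highest of the two numbers so far. Among the compounds with values here, its nearest neighbour, compound 1 `CNC(=O)c1cc(Oc2ccc3nc(NC(=O)Nc4ccc(Br)cc4)sc3c2)ccn1`, gives 69.2% in this assay; the step of a number 11.8 percentage points higher from compound 1 to compound 2 (beyond the scatter) is the only measured step. Compound 3 `CNC(=O)c1cc(Oc2ccc3nc(NC(=O)Nc4ccc(F)cc4)sc3c2)ccn1` is not yet measured and differs from compound 2 by (4-fluorophenyl)amino in place of 2,4-dichlorophenyl on a carbonyl carbon. This change brings the carbonyl carbon back to the arrangement of compound 1, which carries a (4-bromophenyl)amino there, with fluorine now in the place of bromine. Within the data shown here, the one measured step bears on it in reverse, so a downward move of about the same size is expected, a number 14 percentage points lower from compound 2 to compound 3 (beyond the scatter). Among the measured compounds shown here, no measured step separates a (4-fluorophenyl)amino from a (4-bromophenyl)amino, so the range stays wide. Compound 3 is expected to give 67% in this assay, between 50% and 84%.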

Compound 3, percent growth inhibition at one concentration: 72.9%
Compound 3: middle estimate off by 5.9 percentage points, on the low side; measured number inside the range.
By their numbers in this assay, from the lowest: compounds 1, 3 and 2 (each within the scatter of the next, the first and the last beyond it).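

In this assay, the step of a number 3.7 percentage points higher from compound 1 to compound 3 (within the scatter) shows that fluoro and bromo on the aromatic carbon cannot be told apart in this series. The step of a number 8.1 percentage points lower from compound 2 to compound 3 (within the scatter) stays inside the scatter, whereas the earlier amide-for-urea comparison, with the bromo compound, lay beyond it, so the separation seen there does not carry over to the fluoro compound, and the change on the carbonyl carbon cannot be read as a fixed difference across the two halogens. No measurement on hand explains either step.

The compounds shown leave open whether a phenyl ring with no halogen, or one carrying a methoxy group, an amine or a carboxylic acid, would separate from these values. A 4-fluorophenyl placed directly on the carbonyl carbon would test the amide-urea difference with the same halogen.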